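The source may hold more compounds than are shown below. What is called first, only, known or untested is meant among the compounds shown, and "the series" means these compounds.

Compound 3, `Cn1cc(NC(=O)c2ccncc2Nc2cc(-c3ccc4ccn(C)c4c3)c3nccnc3c2)cn1`, gives 33 nM in an assay for inhibition of 6-phosphofructo-2-kinase/fructose-2,6-bisphosphatase 3 (Homo sapiens), read by ADP-Glo, with a stated time of 2 h; a higher number here means a weaker inhibitor, a lower number a stronger inhibitor. Among the three measured compounds it stands second highest: compound 2, `Cn1ccc2ccc(-c3cc(Nc4ccccc4S(=O)(=O)NCC4CCOCC4)cc4nccnc34)cc21`, gives 26 nM, and the two values lie within the scatter of each other, while compound 1, `CNS(=O)(=O)c1ccccc1Nc1cc(-c2ccc3ccn(C)c3c2)c2nccnc2c1`, gives 104 nM, a higher number that lies beyond the scatter from compound 3.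

The unmeasured compound 4, `CC(=O)N1CC(NC(=O)c2ccncc2Nc2cc(-c3ccc4ccn(C)c4c3)c3nccnc3c2)C1`, differs from compound 3 in one place: 1-acetylazetidin-3-yl in place of 1-methyl-1H-pyrazol-4-yl on an amide-type nitrogen. Going by the values given here, the only measured step, a 4.0-fold lower number from compound 1 to compound 2 (0.60 log units; beyond the scatter), concerns a different part of the molecule, a saturated chain carbon bound to a sulfonamide nitrogen, where oxan-4-yl replaced hydrogen; it shows that a saturated oxygen-containing ring at that outer position was tolerated and gave a modest gain, but it does not directly test the swap of an aromatic five-membered ring for a four-membered non-aromatic ring on an amide-type nitrogen. Among the compounds with values here, with no closer precedent, compound 4 is expected to stay near compound 3, and the step of a 1.2-fold higher number from compound 3 to compound 4 (0.08 log units; within the scatter) is estimated to fall within the scatter in either direction. Compound 4 is therefore estimated at 40 nM in this assay, with a range from 12 nM to 130 nM.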

Compound 4, half-maximal inhibitory concentration: 73 nM
For compound 4 the middle estimate is 1.8-fold (0.26 log units) below the measured one; low and high end bracket the measured number.
By their numbers in this assay, from the lowest: compounds 2 and 3 (each within the scatter of the next); then compounds 4 and 1 (each within the scatter of the next).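

In this assay, 1-acetylazetidin-3-yl in place of 1-methyl-1H-pyrazol-4-yl on the amide-type nitrogen gives a 2.2-fold higher number from compound 3 to compound 4 (0.34 log units; beyond the scatter), so the group held on this nitrogen does affect the reading, though the step is modest. Going by these compounds alone, the only earlier step lay elsewhere, on a saturated chain carbon bound to a sulfonamide nitrogen, and this result is the first reading at the amide-type nitrogen: it shows that a four-membered non-aromatic ring carrying an acetyl group can replace the five-membered aromatic ring at a modest cost, with compound 4 still at 73 nM. Nothing measured here accounts for the size or direction of this step.

Within the data shown here, the single step changes the ring and adds the acetyl group at once, leaving open which of the two carries the difference, a question that an azetidin-3-yl group with a free amine on its ring nitrogen could help to separate. Also open, from the compounds shown here alone, is how this position would respond to a simple open chain such as 2-methoxyethyl, or to a six-membered ring such as oxan-4-yl.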